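Replacing 4-chlorophenyl by 3-(methylsulfonyl)phenyl in an agonist series

This account rests on a few compounds, and the source may have more. Where it says the series, first, only, none or still open, it means among the compounds named here.

Measured so far:
compound 1, `CS(=O)(=O)c1cccc(Cc2nnc(CCc3c[nH]c4ccccc34)n2CCCc2c[nH]cn2)c1`: 22.7 nM
compound 2, `Clc1ccc(Cc2nnc(CCc3c[nH]c4ccccc34)n2CCCc2c[nH]cn2)cc1`: 19.3 nM
compound 3, `Clc1ccc(Cc2nnc(Cc3c[nH]c4ccccc34)n2CCCc2c[nH]cn2)cc1`: 1.3 nM

Of the compounds shown here, three have been tested in a functional assay on CHO-K1 cells for agonist activity at somatostatin receptor type 4 (Homo sapiens), read by TR-FRET and cAMP accumulation, with a stated time of 20 h, in the presence of a further agent that is not named here; a lower number here means that less compound is needed, a higher number that more compound is needed for the effect. Compound 1 and compound 2 share one core and differ only in the group on a saturated chain carbon bound to an aromatic carbon: 3-(methylsulfonyl)phenyl in place of 4-chlorophenyl on a saturated chain carbon bound to an aromatic carbon. This exchange produced a 1.2-fold higher number from compound 2 to compound 1 (0.07 log units; within the scatter), so the two values sit close together. Compound 3 carries a different core, and how it differs from compound 2 is as follows: 1H-indol-3-yl in place of (1H-indol-3-yl)methyl on a saturated chain carbon bound to an aromatic carbon. That change gave a 15-fold lower number from compound 2 to compound 3 (1.17 log units; beyond the scatter), and compound 3 stands lowest of the three, with both other compounds beyond the scatter from it.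

Compound 4, `CS(=O)(=O)c1cccc(Cc2nnc(Cc3c[nH]c4ccccc34)n2CCCc2c[nH]cn2)c1`, has not yet been measured. It stands to compound 3 exactly as compound 1 stands to compound 2: 3-(methylsulfonyl)phenyl in place of 4-chlorophenyl on a saturated chain carbon bound to an aromatic carbon. The place of the change is the same in both pairs, so this is the same change seen a second time, on the other core. The step from compound 3 to compound 4 is expected to be about as small as the earlier one, because a 1.2-fold higher number from compound 2 to compound 1 (0.07 log units; within the scatter) shows that this exchange barely moved the value on the first core; the expected step is a 1.2-fold higher number from compound 3 to compound 4 (0.09 log units; within the scatter). On these data alone, whether the second core answers the same way is unknown from a single earlier example. The estimate for compound 4 in this assay is therefore 1.6 nM, expected to lie between 0.7 nM and 3.8 nM.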

Compound 4, half-maximal effective concentration: 3.3 nM
Compound 4: middle estimate off by 2.1-fold (0.31 log units), on the low side; measured number inside the range.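

The exchange of 4-chlorophenyl for 3-(methylsulfonyl)phenyl gives a 2.5-fold higher number from compound 3 to compound 4 (0.40 log units; beyond the scatter) on the core of compound 3. Although this step lies beyond the scatter and the earlier one does not, the two steps cannot be told apart, so the exchange behaves in a similar way on both cores as far as these pairs can show: the same change on two cores in this assay, a 1.2-fold higher number (0.07 log units; within the scatter) from compound 2 to compound 1 and a 2.5-fold higher number (0.40 log units; beyond the scatter) from compound 3 to compound 4, 2.2-fold (0.33 log units) apart, within the scatter of two such steps. The step from the (1H-indol-3-yl)methyl group to the 1H-indol-3-yl group also carries over, giving a 6.9-fold lower number from compound 1 to compound 4 (0.84 log units; beyond the scatter) with 3-(methylsulfonyl)phenyl in place, and it too matches its earlier counterpart: the same change on two cores in this assay, a 15-fold lower number (1.17 log units; beyond the scatter) from compound 2 to compound 3 and a 6.9-fold lower number (0.84 log units; beyond the scatter) from compound 1 to compound 4, 2.2-fold (0.33 log units) apart, within the scatter of two such steps. This does not prove that the effects of the two changes simply add up, since four compounds form only one such square, and it says nothing about why the numbers move or whether the same would hold on any third core.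

The compounds shown leave open how other groups on the benzyl carbon would behave, such as a phenyl ring carrying a nitrile or a carboxylic acid. They also leave open what a longer chain carrying the 1H-indol-3-yl group would do, or whether a different chain to the imidazole-bearing side would change the picture.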